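This account rests on a few compounds, and the source may have more. Where it says the series, first, only, none or still open, it means among the compounds named here.

Within the data shown here, compound 3 `CCC[C@H](CO)Nc1nc(C)nc2c1c(C)nn2-c1ccc(OC)cc1C` gives 76 nM in a functional assay on CHO cells for antagonist activity at corticotropin-releasing factor receptor 1 (Homo sapiens), read by cAMP accumulation (a higher number here means a weaker inhibitor, a lower number a stronger inhibitor), the lowest of the three numbers so far. Compound 2 `CC[C@H](COC)Nc1nc(C)nc2c1c(C)nn2-c1ccc(OC)cc1C` gives 210 nM and compound 1 `CCCN(CC(=O)N(C)C)c1nc(C)nc2c1c(C)nn2-c1ccc(OC)cc1C` gives 1410 nM, so compound 3 is separated from its nearest neighbour by a 2.8-fold lower number from compound 2 to compound 3 (0.44 log units; beyond the scatter) and from the weakest by a 19-fold lower number from compound 1 to compound 3 (1.27 log units; beyond the scatter); the other measured step is a 6.7-fold lower number from compound 1 to compound 2 (0.83 log units; beyond the scatter).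

Compound 4 `CCC[C@@H](CO)Nc1nc(C)nc2c1c(C)nn2-c1ccc(OC)cc1C` brings (the two compounds have the same atoms and bonds and differ only in configuration as drawn: 1 of 1 stereo elements differ; a stereocentre at a saturated chain carbon is drawn R in compound 3 and S in compound 4). None of the three measured steps touches configuration; each of them exchanges one group on the amino nitrogen for another, and all three keep the same drawn configuration where a stereocentre is present. The measured material therefore gives no direct guide, and the estimate for compound 4 rests only on the fact that inverting a single stereocentre commonly changes activity in an unknown direction.

Compound 4 is expected to give 300 nM, a step of a 3.9-fold higher number from compound 3 to compound 4 (0.60 log units; beyond the scatter), with a wide range from 60 nM to 1500 nM.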

Compound 4, inhibition constant: 574 nM
For compound 4 the middle estimate is 1.9-fold (0.28 log units) below the measured one; the measured number falls inside the stated range.
By their numbers in this assay, from the lowest: compound 3; then compound 2; then compound 4; then compound 1.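

In this assay, the configuration at the stereocentre of the 1-(hydroxymethyl)butyl group matters in its own right, with a 7.6-fold higher number from compound 3 to compound 4 (0.88 log units; beyond the scatter), and this step can be assigned to that centre alone because nothing else changes: the fact that compounds 3 and 4 differ only in the configuration as drawn. The inverted form still gives a lower number than the ((dimethylcarbamoyl)methyl)(propyl)amino group, with a 2.5-fold lower number from compound 1 to compound 4 (0.39 log units; beyond the scatter), so part of the gain seen with the 1-(hydroxymethyl)butyl group survives inversion. The remaining step, a 2.7-fold higher number from compound 2 to compound 4 (0.44 log units; beyond the scatter), combines the exchange of the 1-(methoxymethyl)propyl group with an inversion of the drawn configuration, so it cannot be read as a single change.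

On these data alone, it remains open whether inverting the centre in the 1-(methoxymethyl)propyl group would shift the number in the same way. Also open, as far as these compounds go, is how an amine or a carboxylic acid in place of the hydroxyl, or a longer chain in place of the butyl chain, would behave in either configuration.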